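The compounds below may be only part of what the source reports. "The series", "measured", "known", "first", "only" and "open" are said of these compounds alone.

In an assay on isolated protein for binding affinity to secreted frizzled-related protein 1 (Homo sapiens), read by fluorescence (on this read-out lower numbers stand for stronger inhibition and higher numbers for weaker inhibition), compound 1 `O=C1CC[C@@H](C(=O)N2CCC(NS(=O)(=O)c3cc(S(=O)(=O)c4ccccc4)ccc3C(F)(F)F)CC2)N1` gives 90 nM, compound 2 `CC(=O)N1CCC[C@H]1C(=O)N1CCC(NS(=O)(=O)c2cc(S(=O)(=O)c3ccccc3)ccc2C(F)(F)F)CC1` gives 160 nM and compound 3 `O=C([C@@H]1CCCN1C(=O)c1ccncc1)N1CCC(NS(=O)(=O)c2cc(S(=O)(=O)c3ccccc3)ccc2C(F)(F)F)CC1` gives 70 nM, the lowest of the three numbers, though compound 1 lies within the scatter of it and only compound 2 lies beyond. Compound 4 `CN(C)C(=O)N1CCC[C@H]1C(=O)N1CCC(NS(=O)(=O)c2cc(S(=O)(=O)c3ccccc3)ccc2C(F)(F)F)CC1` differs from compound 3 by dimethylamino in place of pyridin-4-yl on a carbonyl carbon. The step that bears on this change is a 2.3-fold lower number from compound 2 to compound 3 (0.36 log units; beyond the scatter), made at the same carbonyl carbon; a 1.8-fold higher number from compound 1 to compound 2 (0.25 log units; within the scatter) concerns a different place and stays within the scatter. Because a 2.3-fold lower number from compound 2 to compound 3 (0.36 log units; beyond the scatter) was modest, and a group without ring or acceptor now takes the place of pyridin-4-yl, a partial return toward the number of compound 2 is expected, giving the step of a 1.6-fold higher number from compound 3 to compound 4 (0.20 log units; within the scatter). Compound 4 is therefore estimated at 110 nM, with a range from 55 nM to 220 nM.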

Compound 4, half-maximal inhibitory concentration: 30 nM
For compound 4 the middle estimate is 3.7-fold (0.56 log units) above the measured one, outside the stated range (below it).
By their numbers in this assay, from the lowest: compound 4; then compounds 3, 1 and 2 (each within the scatter of the next, the first and the last beyond it).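

The pyridin-4-yl ring and its acceptor are not required at this carbonyl carbon: dimethylamino, which has neither, gives a 2.3-fold lower number from compound 3 to compound 4 (0.37 log units; beyond the scatter). Set against methyl at the same carbon, dimethylamino gives a 5.3-fold lower number from compound 2 to compound 4 (0.73 log units; beyond the scatter), and the whole 1-(dimethylcarbamoyl)pyrrolidin-2-yl group, in place of 5-oxopyrrolidin-2-yl, gives a 3.0-fold lower number from compound 1 to compound 4 (0.48 log units; beyond the scatter). No measurement available here accounts for these steps. As far as these compounds go, whether the step depends on the nitrogen or on its two methyl groups remains open, and methoxy, amino or diethylamino on this carbonyl carbon would address that question.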